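The source may hold more compounds than are shown below. What is called first, only, known or untested is meant among the compounds shown, and "the series" means these compounds.

Measured so far:
- compound 1, `C=C(Br)C(=O)Nc1cccc(-c2cn3nc(Cc4cccc(OC)c4)sc3n2)c1`, gives 2500 nM
- compound 2, `COc1ccc(-c2nn3cc(-c4cccc(N)c4)nc3s2)cc1OC`, gives 26000 nM
- compound 3, `COc1ccc(Cc2nn3cc(-c4cccc(N)c4)nc3s2)cc1`, gives 191000 nM

These three compounds were tested in a functional assay on HeLa cells (Homo sapiens) for inhibition, read by cell counting, with a stated time of 4 days; on this read-out higher numbers stand for weaker inhibition and lower numbers for stronger inhibition. Among them, compound 1 stands at the lowest number, and its steps to the other two are beyond the usual scatter: compound 2 sits well above it, and compound 3 sits further above still. Compound 2 and compound 3 differ from each other in more than one place, so their two values show only that the one with a directly attached aromatic ring on the shared core comes out with the lower number.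

The next compound, compound 4, has the structure `C=C(Br)C(=O)Nc1cccc(-c2cn3nc(-c4ccc(C)cc4)sc3n2)c1`. It keeps the whole of compound 1 apart from one change: 4-methylphenyl in place of 3-methoxybenzyl on an aromatic carbon. In words, 4-methylphenyl takes the place of 3-methoxybenzyl on an aromatic carbon of the shared core.

For the measured compounds named here, no measured pair shows this exact change. Taking the comparison of compound 2 with compound 3 as a loose hint, the expected step of a 2.1-fold lower number from compound 1 to compound 4 (0.32 log units; beyond the scatter) is toward a somewhat lower number, but the size is uncertain and could fall within the scatter. For compound 4 the estimate in this assay is 1200 nM, with a range from 300 nM to 6000 nM.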

Compound 4, half-maximal inhibitory concentration: 2000 nM
Estimate against measurement, compound 4: 1.7-fold (0.22 log units) below, and the stated range covers the measured number.
By their numbers in this assay, from the lowest: compounds 4 and 1 (each within the scatter of the next); then compound 2; then compound 3.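

In this assay, for the compounds shown here, 4-methylphenyl in place of 3-methoxybenzyl on this aromatic carbon gives a 1.3-fold lower number from compound 1 to compound 4 (0.10 log units; within the scatter), which is the first comparison here in which only one place differs. At this position, therefore, a benzyl group carrying a methoxy and a directly attached phenyl ring carrying a methyl cannot be told apart on this read-out, even though the change takes away the one hydrogen-bond acceptor of the leaving group and goes from 9 heavy atoms to 7 heavy atoms. Nothing available explains why the two groups land so close together.

The compounds shown leave open whether a quite different group on this carbon, such as an amine, a carboxylic acid or a longer alkyl chain, would stay this close to compound 1 or move beyond the scatter in this assay. They also leave open what the rest of compound 1 contributes, since compound 2 and compound 3 each differ from compound 1 and compound 4 in more than one place, so those gaps cannot be pinned on any single group.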